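This account rests on a few compounds, and the source may have more. Where it says the series, first, only, none or still open, it means among the compounds named here.

Measured so far: compound 1 `O=C(N/N=C/c1ccc(F)cc1)c1cccnc1Nc1cccc(C(F)(F)F)c1` gives 36.5% in a functional assay on the whole organism (strain Wistar) for inhibition, with Rattus norvegicus as the target, read by paw edema, with a stated time of 4 h, at a dose of 10 mg/kg by the intraperitoneal route; a lower number here means less inhibition, a higher number more inhibition at the dose given (going by the name of the read-out); compound 2 `O=C(N/N=C/c1ccc(O)cc1)c1cccnc1Nc1cccc(C(F)(F)F)c1` gives 61.6%; compound 3 `COc1ccc(/C=N/NC(=O)c2cccnc2Nc2cccc(C(F)(F)F)c2)cc1OC` gives 52.9%.

Compound 3 stands second highest of the three numbers, with compound 2 nearest and compound 1 furthest away. Compound 4 `COc1cc(/C=N/NC(=O)c2cccnc2Nc2cccc(C(F)(F)F)c2)cc(OC)c1OC` differs from compound 3 by methoxy in place of hydrogen on an aromatic carbon. For the measured compounds named here, no measured step adds a single methoxy group to a ring that already carries methoxy groups; the steps that bear on it most are a number 16.4 percentage points higher from compound 1 to compound 3 (beyond the scatter) and a number 8.7 percentage points lower from compound 2 to compound 3 (within the scatter), the second within the scatter. A small step, or none beyond the scatter, is therefore expected in this assay for compound 4, as a number 2.9 percentage points lower from compound 3 to compound 4 (within the scatter). Compound 4 is estimated at 50%, within a range from 38% to 62%.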

Compound 4, a percentage reported as inhibition, in the whole organism at one dose (the size of the read-out at that dose, not a potency): 28.6%
Estimate against measurement, compound 4: 21.4 percentage points above, and the stated range ends above it.
By their numbers in this assay, from the lowest: compounds 4 and 1 (each within the scatter of the next); then compounds 3 and 2 (each within the scatter of the next).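

In this assay the carbon ortho to a methoxy group and meta to a large group proves not to be indifferent: methoxy in place of hydrogen there gives a number 24.3 percentage points lower from compound 3 to compound 4 (beyond the scatter) and so lowers the inhibition seen at the dose given. The earlier compounds shown here could not show this, as none of them adds a methoxy to a ring that already carries methoxy groups. Nothing available explains this step.

On these data alone, whether an amine or a chlorine atom on this carbon would give a similar step remains open. As far as these compounds go, it is also open whether the same methoxy would lower the number on a ring without the other methoxy groups.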